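Fluoro in place of methoxy: an untested step

The source may hold more compounds than are shown below. What is called first, only, known or untested is meant among the compounds shown, and "the series" means these compounds.

In an ADME assay on HEK-293T cells (Homo sapiens) for inhibition, read by CCK-8 assay, with a stated time of 48 h, tested at 20 uM (a lower number here means less inhibition of growth, a higher number more inhibition of growth at the concentration tested), compound 1 (`COc1ccc(Cc2nnc(NC(=O)/C(C#N)=C/c3ccccc3OS(=O)(=O)c3ccc(C)cc3)s2)cc1`) gives 21% and compound 2 (`COc1ccc(Cc2nnc(NC(=O)/C(C#N)=C/c3ccccc3OS(=O)(=O)c3ccc(OC)cc3)s2)cc1`) gives 30% and thus stands level with compound 1 within the scatter. Neither of the two is set apart from the other. Compound 3 (`COc1ccc(S(=O)(=O)Oc2ccccc2/C=C(\C#N)C(=O)Nc2nnc(Cc3ccc(F)cc3)s2)cc1`) has yet to be measured. It differs from compound 2 by fluoro in place of methoxy on an aromatic carbon, para to a large group, which turns 4-methoxybenzyl into 4-fluorobenzyl (fluoro in place of methoxy on an aromatic carbon). Among the compounds with values here, only one measured step is available as a guide (a number 9 percentage points higher from compound 1 to compound 2 (within the scatter)), and it bears on this change only loosely. That step is methoxy in place of methyl on an aromatic carbon at another place in the molecule, and it stays within the scatter. Within the data shown here, no measurement yet shows what a change at the benzyl group does. No shift beyond the scatter is therefore expected in this assay from this one comparison. The expected change (a number 4 percentage points lower from compound 2 to compound 3 (within the scatter)) is an estimate that stays within the scatter. Compound 3 is expected to give 26% with an estimated range of 12% to 40% in this assay when it is tested.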

Compound 3, percent growth inhibition at one concentration: 20%
Beside the measured number, compound 3's estimate is 6 percentage points above it, and the stated range covers the measured number.
By their numbers in this assay, from the lowest: compounds 3, 1 and 2 (each within the scatter of the next).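

In this assay, the benzyl group now has a measured step of its own: a number 10 percentage points lower from compound 2 to compound 3 (within the scatter), as 4-fluorobenzyl takes the place of 4-methoxybenzyl. The earlier pair spoke only of a change at another place in the molecule, whereas this step shows that exchanging methoxy for fluoro on an aromatic carbon, para to a large group, leaves the number within the scatter, so the two groups cannot be told apart at this position in this read-out. Nothing available explains this result or links it to any measured property of the two groups.

On these data alone, what an amine, a carboxylic acid or a longer chain in place of fluoro or methoxy on this aromatic carbon would do remains open, and so does whether any group at this position can move the number beyond the scatter. As far as these compounds go, it is also open whether fluoro in place of methoxy would give a similar step at the other place where the compounds differ, since neither measured step speaks for that place and this one together.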